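The source may hold more compounds than are shown below. What is called first, only, known or untested is meant among the compounds shown, and "the series" means these compounds.

In an ADME assay on HEK293 cells (Homo sapiens) for cytotoxicity, read by MTT assay, with a stated time of 72 h (a lower number here means a stronger inhibitor, a higher number a weaker inhibitor), compound 1 `COc1ccc(/C=C/C(=O)CC(C)=O)cc1OC` gives 8200 nM, and compound 2 `COc1ccc(/C=C/C(=O)CC(C)=O)cc1` gives 18700 nM. The change between them, (methoxy in place of hydrogen on an aromatic carbon), moves the number by a 2.3-fold lower number from compound 2 to compound 1 (0.36 log units; beyond the scatter). Compound 3 `Cc1cc(/C=C/c2ccc(O)cc2)on1` gives 50200 nM in this assay, the highest of the three numbers; how its core differs from that of compound 2 is not broken down here. Compound 4 `COc1cc(/C=C/c2cc(C)no2)ccc1O` has not been measured in this assay. It differs from compound 3 by methoxy in place of hydrogen on an aromatic carbon, the same kind of change as from compound 2 to compound 1, though here the entering methoxy sits ortho to a hydroxy group rather than ortho to a methoxy group. On that single earlier step, compound 4 is expected to move by a 2.0-fold lower number from compound 3 to compound 4 (0.30 log units; within the scatter), which rests on the step to compound 1 of a 2.3-fold lower number from compound 2 to compound 1 (0.36 log units; beyond the scatter) and on the value of compound 3 of 50200 nM. Compound 4 is thus estimated at 25000 nM, between 10000 nM and 60000 nM.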

Compound 4, half-maximal inhibitory concentration: 36200 nM
Compound 4: the middle estimate sits 1.4-fold (0.16 log units) below what was measured; low and high end bracket the measured number.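

In this assay, methoxy in place of hydrogen on an aromatic carbon, here ortho to a hydroxy group, gives a 1.4-fold lower number from compound 3 to compound 4 (0.14 log units; within the scatter). Set beside the earlier step, the new one does not stand apart from it: the same change on two cores in this assay, a 2.3-fold lower number (0.36 log units; beyond the scatter) from compound 2 to compound 1 and a 1.4-fold lower number (0.14 log units; within the scatter) from compound 3 to compound 4, 1.6-fold (0.22 log units) apart, within the scatter of two such steps. The two steps are thus compatible with a change that carries from one core to the other, but two pairs do not show that it transfers generally, and the step on the core of compound 3 alone does not show that methoxy has any effect there.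

The compounds shown leave open what an amine, a carboxylic acid or a chlorine atom would do in this place. They also leave open whether methoxy behaves the same way on any further core.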